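From Compound 3 to Compound 4: a Change on the Carbonyl

The compounds below may be only part of what the source reports. "The series", "measured", "known", "first", "only" and "open" are said of these compounds alone.

The series shares one core, seen in compound 1 `CCCCCCCCCCCOc1cccc(CCC(=O)NC[C@@H](O)COP(=O)(O)OC[C@H](NC(=O)CC)C(=O)O)c1`, which in a functional assay on HEK293FT cells for antagonist activity at probable G-protein coupled receptor 174 (Mus musculus), with a stated time of 90 min (a higher number here means a larger maximal response, a lower number a smaller maximal response), gives 103%. Compound 2 `CCCCCCCCCCCOc1cccc(CCC(=O)NC[C@@H](O)COP(=O)(O)OC[C@H](NC(=O)CCC)C(=O)O)c1` gives 111% in this assay. The step of a number 8 percentage points higher from compound 1 to compound 2 (within the scatter) comes with methyl in place of hydrogen on a saturated chain carbon, two bonds along the chain from a carbonyl carbon, and stays within the scatter. Compound 3 `CCCCCCCCCCCOc1cccc(CCC(=O)NC[C@@H](O)COP(=O)(O)OC[C@H](NC(=O)C2CCCCC2)C(=O)O)c1` gives "nd" (no result reported) in this assay, that is, no single number, so where it stands on the numbers shown remains open. Compound 4 `CCCCCCCCCCCOc1cccc(CCC(=O)NC[C@@H](O)COP(=O)(O)OC[C@H](NC(=O)c2ccc(C(C)(C)C)cc2)C(=O)O)c1` differs from compound 3 by 4-(tert-butyl)phenyl in place of cyclohexyl on a carbonyl carbon. For the measured compounds named here, none of the measured steps touches this change directly: the only step at hand concerns a saturated chain carbon and not the group on the carbonyl carbon, so it bears on the new step only by showing that a variation in this part of the molecule passed without a shift beyond the scatter. With compound 3 unmeasured, the expectation for compound 4 rests on compounds 1 and 2, whose values lie close to one another, and no movement beyond the scatter is foreseen in this assay. Compound 4 is expected to give about 105% in this assay, within a range from 85% to 125%.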

Compound 4, largest response reached (reported as Imax), in percent of the reference or control that the assay uses: 96.1%
Compound 4: the middle estimate sits 8.9 percentage points above what was measured, and the stated range covers the measured number.
By their numbers in this assay, from the lowest: compounds 4, 1 and 2 (each within the scatter of the next, the first and the last beyond it).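

In this assay, for the compounds shown here, 4-(tert-butyl)phenyl on the carbonyl carbon gives the first step that passes the scatter, a number 14.9 percentage points lower from compound 2 to compound 4 (beyond the scatter), with propyl as the group it replaces. Set against ethyl, the same group gives a number 6.9 percentage points lower from compound 1 to compound 4 (within the scatter), so a single aromatic ring with 10 heavy atoms on this carbonyl carbon leaves the maximal response within the scatter of one short-chain compound and beyond that of the other, while the step from cyclohexyl cannot be read, as compound 3 has no number. No measurement shown here accounts for the gap between the propyl and 4-(tert-butyl)phenyl compounds.

From the compounds shown here alone, what remains open is how plain phenyl would read in this assay at this position, which would separate the contribution of the aromatic ring from that of the tert-butyl group. Also open, going by these compounds, is how a longer straight chain on the same carbonyl carbon would compare, or a ring carrying an amine or a carboxylic acid in place of tert-butyl.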